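Hydroxyphenyl placement on a thienyl-bearing pyridine series

A few compounds are considered here, and "the series" means these few. Any claim that something is new, unique, unknown or untested is made for them only; others in the source may bear on it.

Measured compounds:
compound 1 `Oc1cccc(-c2cc(-c3cccs3)cc(-c3cccc(O)c3)n2)c1`: 1630 nM
compound 2 `Oc1cccc(-c2cc(-c3ccsc3)cc(-c3ccccc3O)n2)c1`: > 50000 nM

In a functional assay on DU-145 cells (Homo sapiens) for cytotoxicity, read by CCK-8 assay (on this read-out lower numbers stand for stronger inhibition and higher numbers for weaker inhibition), compound 1 gives 1630 nM. For compound 2 only a limit is recorded, (the limit of > 50000 nM in this assay, at which 1 of the 2 values shown sits), so its standing on the numbers shown is open-ended. Compound 3 `Oc1cccc(-c2cc(-c3ccsc3)cc(-c3cccc(O)c3)n2)c1` is the next structure; it differs from compound 2 by 3-hydroxyphenyl in place of 2-hydroxyphenyl on an aromatic carbon. Within the data shown here, no step between measured compounds is known here, so the expected size rests on the single number available. Compound 3 carries the same pair of 3-hydroxyphenyl groups as compound 1, and compound 3 is expected at 2500 nM, between 600 nM and 15000 nM, because compound 1 in this assay gives 1630 nM. That estimate means a step of an at least 20-fold lower number from compound 2 to compound 3 (1.30 log units; beyond the scatter), expected to be a large gain in potency beyond the scatter.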

Compound 3, half-maximal inhibitory concentration: 1310 nM
Compound 3: the middle estimate sits 1.9-fold (0.28 log units) above what was measured, and the stated range covers the measured number.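

With the thiophen-3-yl group held fixed, 3-hydroxyphenyl in place of 2-hydroxyphenyl next to the ring nitrogen gives an at least 38-fold lower number from compound 2 to compound 3 (1.58 log units; beyond the scatter) in this assay, so the position of the hydroxyl on this ring decides the read-out. Compound 2 stands only as a limit: the limit of > 50000 nM in this assay, at which 1 of the 3 values shown sits. Thiophen-3-yl in place of thiophen-2-yl gives a 1.2-fold lower number from compound 1 to compound 3 (0.09 log units; within the scatter), so this change of thiophene attachment shows no readable effect.

As far as these compounds go, whether 2-hydroxyphenyl is equally poor alongside thiophen-2-yl remains open. So does the outcome of an amine or a carboxylic acid in place of the hydroxyl.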